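This account rests on a few compounds, and the source may have more. Where it says the series, first, only, none or still open, it means among the compounds named here.

Compound 1 `Cc1cc(NCc2c[nH]cn2)n2nc(C)c(-c3ccccc3)c2n1` gives 14600 nM in a physicochemical assay for solubility, read by HPLC, using the shake flask method, measured as kinetic solubility, with a stated time of 2 h, at pH 7.4; a lower number here means a less soluble compound, a higher number a more soluble compound.
Compound 2 `Cc1cccc(CNc2cc(C)nc3c(-c4ccccc4)c(C)nn23)n1` gives < 5000 nM in this assay, which is a limit of the assay and not a number.
Compound 3 `Cc1cc(NCC2CCCCN2)n2nc(C)c(-c3ccccc3)c2n1` gives 189000 nM in this assay.

Among the measured numbers compound 3 stands highest; the nearest is compound 1, with a 13-fold higher number from compound 1 to compound 3 (1.11 log units; beyond the scatter) between them. Compound 4 `Cc1cc(NCc2ccc(F)cn2)n2nc(C)c(-c3ccccc3)c2n1` differs from compound 3 in one place: 5-fluoropyridin-2-yl in place of piperidin-2-yl on a saturated chain carbon bound to a nitrogen on an aromatic ring. For the measured compounds named here, two measured steps bear on this change. The step of an at least 37-fold higher number from compound 2 to compound 3 (1.57 log units; beyond the scatter) exchanges a pyridine-type ring for the piperidin-2-yl group, and the step of a 13-fold higher number from compound 1 to compound 3 (1.11 log units; beyond the scatter) exchanges an imidazole ring for it; both run toward compound 3 and both are large. The step from compound 3 to compound 4 runs the other way, from piperidin-2-yl to a pyridine-type ring, so a large drop is expected, a 38-fold lower number from compound 3 to compound 4 (1.58 log units; beyond the scatter). Compound 4 is therefore expected to give about 5000 nM in this assay, within a range of 1500 nM to 20000 nM, and it may well be reported only as a limit, as compound 2 was.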

Compound 4, solubility: < 5000 nM
Compound 4 ended at the assay's limit; the forecaster's own chance of this, stated with the estimate: 50%; the middle value lies on the limit itself.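

In this assay compound 4 gives < 5000 nM, which is a limit of the assay and not a number. Its 5-fluoropyridin-2-yl group now makes a second pyridine-type ring at this place on the saturated chain carbon, and the outcome is again low, not only against piperidin-2-yl, with an at least 37-fold lower number from compound 3 to compound 4 (1.57 log units; beyond the scatter), but also against 1H-imidazol-4-yl, with an at least 2.9-fold lower number from compound 1 to compound 4 (0.46 log units; beyond the scatter). The step between compound 2 and compound 4 cannot be read, so the 5-fluoro and 6-methyl pyridines cannot be ordered against each other: the limit of < 5000 nM in this assay, at which 2 of the 4 values shown sit.

On these data alone, it remains open how far compound 2 and compound 4 actually lie under that limit. As far as these compounds go, it is also open whether the high number of compound 3 needs the piperidine ring itself, or whether an open-chain amine such as a dimethylaminomethyl group at this place would give a comparable number.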